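This account rests on a few compounds, and the source may have more. Where it says the series, first, only, none or still open, it means among the compounds named here.

Of the compounds shown here, three built on one shared core have been tested. Compound 1 `COc1nc2ccc(Br)cc2cc1C(c1ccccc1)n1cc(-c2ccc(Br)cc2)nn1` gives 7.43% in an ADME assay on PC-3 cells (Homo sapiens) for cytotoxicity, read by sulforhodamine B assay, with a stated time of 48 h, tested at 10 uM; on this read-out higher numbers stand for more inhibition at the one concentration tested (going by the name of the read-out) and lower numbers for less inhibition. Compound 2 `COc1nc2ccc(Br)cc2cc1C(c1ccccc1)n1cc(-c2ccccc2)nn1` gives 5.97% in this assay, and compound 3 `COc1nc2ccc(Br)cc2cc1C(c1ccccc1)n1cc(-c2ccccc2F)nn1` gives 13.4% in this assay. On the numbers alone compound 3 has the highest of the three, yet the gap to compound 1 and the gap to compound 2 both lie within the scatter, so the three cannot be told apart.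

Compound 4 `CCCCCCCCc1cn(C(c2ccccc2)c2cc3cc(Br)ccc3nc2OC)nn1` is the next one to be measured. The change from compound 3 is octyl in place of 2-fluorophenyl on an aromatic carbon.

Going by the values given here, two measured steps touch the same carbon of the five-membered ring. The step of a number 6 percentage points higher from compound 1 to compound 3 (within the scatter) and the step of a number 7.4 percentage points higher from compound 2 to compound 3 (within the scatter) each swapped one aromatic group for another there, and neither moved the read-out beyond the scatter; the step of a number 1.5 percentage points lower from compound 1 to compound 2 (within the scatter) elsewhere in the molecule was likewise small. Among the compounds with values here, no measured step, however, replaces an aromatic group at this carbon with a chain, so the exchange for octyl is untested ground.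

With nothing in the data pointing either way, compound 4 is expected to show no step beyond the scatter, a number 3.4 percentage points lower from compound 3 to compound 4 (within the scatter), and its estimated value in this assay is 10%, with a range from 0% to 25%.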

Compound 4, a percentage reported as inhibition, at one concentration (the size of the read-out at that concentration, not a potency): 2.27%
Compound 4: middle estimate off by 7.7 percentage points, on the high side, within the range that was stated.
By their numbers in this assay, from the lowest: compounds 4, 2, 1 and 3 (each within the scatter of the next, the first and the last beyond it).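

Going by these compounds alone, the step of a number 11.1 percentage points lower from compound 3 to compound 4 (beyond the scatter) in this assay is the first to pass beyond the scatter, so exchanging a ring for a chain on this carbon of the five-membered ring can register, though only modestly. That finding rests on a single pair, since the step of a number 3.7 percentage points lower from compound 2 to compound 4 (within the scatter) and the step of a number 5.2 percentage points lower from compound 1 to compound 4 (within the scatter) do not separate octyl from phenyl or 4-bromophenyl, and an aromatic ring at this carbon is therefore not shown to be needed for the read-out. Nothing available explains why octyl separates from 2-fluorophenyl alone.

The compounds shown leave open whether the number depends on the length of the chain, as a shorter chain such as butyl or a longer chain such as dodecyl could show, and whether a chain ending in an amine or a carboxylic acid would behave like octyl. They also leave open whether the fluoro group of 2-fluorophenyl matters in itself, as 3-fluorophenyl or 2-chlorophenyl at the same carbon could show.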